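Swapping an Aryl Group on a Trimethoxyphenyl Series

The compounds below may be only part of what the source reports. "The series", "measured", "known", "first", "only" and "open" are said of these compounds alone.

Compound 1 `COc1cc(-c2ccnc3cc(-c4ccc(C(C)=O)cc4)nn23)cc(OC)c1OC`: 5230 nM
Compound 2 `COc1ccc(-c2cc3nccc(-c4cc(OC)c(OC)c(OC)c4)n3n2)cc1`: 125 nM

In a functional assay on MCF7 cells (Homo sapiens) for inhibition, read by CCK-8 assay, with a stated time of 48 h (a lower number here means a stronger inhibitor, a higher number a weaker inhibitor), compound 2 holds the lower of the two numbers, at 125 nM. Compound 3 `COc1cc(-c2ccnc3cc(-c4ccc5cnn(C)c5c4)nn23)cc(OC)c1OC` keeps the shared core but differs in one place: 1-methyl-1H-indazol-6-yl in place of 4-methoxyphenyl on an aromatic carbon. The whole 4-methoxyphenyl gives way to 1-methyl-1H-indazol-6-yl. Going by the values given here, the only measured step bearing on this is large, a 42-fold lower number from compound 1 to compound 2 (1.62 log units; beyond the scatter), and it was made on the same aryl group. Among the compounds with values here, it shows that this group can matter, but no measured step covers an indazolyl group, so no step beyond the scatter is the central expectation. The expected step is a 1.6-fold lower number from compound 2 to compound 3 (0.19 log units; within the scatter). For compound 3 the estimated value is 80 nM, with an expected range from 15 nM to 400 nM.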

Compound 3, half-maximal inhibitory concentration: 279 nM
For compound 3 the middle estimate is 3.5-fold (0.54 log units) below the measured one, within the range that was stated.
By their numbers in this assay, from the lowest: compound 2; then compound 3; then compound 1.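

In this assay, the fused 1-methyl-1H-indazol-6-yl is accepted on this aromatic carbon but does not match 4-methoxyphenyl, with a 2.2-fold higher number from compound 2 to compound 3 (0.35 log units; beyond the scatter), a modest loss. Set against 4-acetylphenyl, the same group gives a 19-fold lower number from compound 1 to compound 3 (1.27 log units; beyond the scatter), so a two-ring aryl group can still sit far ahead of the weakest compound here. Nothing available explains this order. As far as these compounds go, whether a phenyl ring carrying an amine or a fluorine would go beyond compound 2 stays open, as does the effect of removing the methyl from the indazolyl group.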